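The source may report more compounds than this note shows. Statements on the series, on what has been measured and on what is new or still open speak of the compounds shown alone.

The compounds share one core, and they differ in the group joined through a carbonyl to the outer aniline nitrogen. Compound 1 `O=C(Nc1ccc(-n2ccc3c(NC(=O)c4ccccc4)ncnc32)cc1)Nc1ccc(Cl)c(C(F)(F)F)c1` carries a urea linked to a 4-chloro-3-(trifluoromethyl)phenyl ring, and in an ADME assay on HS27 cells (Homo sapiens) for antiproliferative activity, read by MTT assay, with a stated time of 24 h (on this read-out higher numbers stand for weaker inhibition and lower numbers for stronger inhibition), compound 1 gives 6000 nM. Compound 2 `O=C(Nc1ccc(-n2ccc3c(NC(=O)c4ccccc4)ncnc32)cc1)c1ccc(Cl)c(C(F)(F)F)c1` has the same ring attached directly to the carbonyl as an amide, and in this assay compound 2 gives 5500 nM. The step of a 1.1-fold lower number from compound 1 to compound 2 (0.04 log units; within the scatter) shows that this exchange of urea for amide makes no real difference. Compound 3 `O=C(Nc1ccc(-n2ccc3c(NC(=O)c4ccccc4)ncnc32)cc1)Nc1cc(C(F)(F)F)cc(C(F)(F)F)c1` keeps the urea but carries two trifluoromethyl groups on the outer ring. In this assay compound 3 gives only a limit, > 10000 nM, so its true number is not known. That is the limit of > 10000 nM in this assay, at which 1 of the 3 values shown sits.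

Compound 4 `O=C(Nc1ccc(-n2ccc3c(NC(=O)c4ccccc4)ncnc32)cc1)Nc1cccc(C(F)(F)F)c1` differs from compound 3 in one place: hydrogen in place of trifluoromethyl on an aromatic carbon. Among the measured compounds shown here, no measured pair shows this exact change. Compound 1, which carries a single trifluoromethyl on that ring, gives 6000 nM, which suggests that compound 4 lands in a similar weak range. The change is expected to give a step of an at least 1.2-fold lower number from compound 3 to compound 4 (0.09 log units; that floor lies within the scatter). In this assay compound 4 is therefore estimated at 8000 nM, with a range from 3000 nM to 20000 nM.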

Compound 4, half-maximal inhibitory concentration: 4500 nM
For compound 4 the middle estimate is 1.8-fold (0.25 log units) above the measured one; measured number inside the range.
By their numbers in this assay, from the lowest: compounds 4, 2 and 1 (each within the scatter of the next). At a limit, above all of these: compound 3.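

In this assay, among the compounds shown here, hydrogen in place of one trifluoromethyl on the outer ring gives an at least 2.2-fold lower number from compound 3 to compound 4 (0.34 log units; beyond the scatter), the first step in this set to lie beyond the scatter. That size is only a floor, for compound 3 stands at a limit and not at a true number: the limit of > 10000 nM in this assay, at which 1 of the 4 values shown sits. The other two new steps both lie within the scatter, namely hydrogen in place of chloro, which gives a 1.3-fold lower number from compound 1 to compound 4 (0.12 log units; within the scatter), and the exchange of the amide and its chloro-bearing ring for the urea and its ring with a single trifluoromethyl, which gives a 1.2-fold lower number from compound 2 to compound 4 (0.09 log units; within the scatter), so among these changes only the loss of the second trifluoromethyl produces a step beyond the scatter.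

Going by these compounds, how far compound 3 really lies from compound 4 stays unknown, as does what an outer ring with no trifluoromethyl at all would give. The compounds shown also leave open whether an amine or a carboxylic acid on that aromatic carbon, in place of the hydrogen of compound 4, would give a number in the same range.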